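The compounds below may be only part of what the source reports. "The series", "measured", "known", "first", "only" and "open" are said of these compounds alone.

Three compounds have been measured so far in a functional assay on MCF7 cells (Homo sapiens) for antiproliferative activity, read by MTT assay, with a stated time of 48 h (a higher number here means a weaker inhibitor, a lower number a stronger inhibitor), and give these values:

- Compound 1 `COc1ccc(C(=O)c2ccc(OC)c3c2C=CC(C)(C)O3)c(NC(=O)CO)c1` gives 940 nM
- Compound 2 `C=C(c1cc(OC)c(OC)c(OC)c1)c1ccc(OC)cc1NC(=O)CNCC` gives 860 nM
- Compound 3 `C=C(c1cc(OC)c(OC)c(OC)c1)c1ccc(OC)c(O)c1NC(=O)COC` gives 560 nM

With its value of 560 nM compound 3 lies within the usual scatter of both compound 1 and compound 2, so these numbers do not separate the three.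

Compound 4 `C=C(c1cc(OC)c(OC)c(OC)c1)c1ccc(OC)c(O)c1NC(=O)CO` has not yet been measured. It differs from compound 3 by one small change (hydrogen in place of methyl on an oxygen on a saturated carbon): methoxymethyl becomes hydroxymethyl, with hydrogen in place of methyl on an oxygen on a saturated carbon.

Going by the values given here, no measured pair shows this change alone. Compound 1 carries the same (hydroxymethyl)carbonyl on another core, and it gives 940 nM within the scatter of compound 3. On that evidence, no step beyond the scatter is expected in this assay for this change. The estimate therefore means a small expected step (a 1.1-fold lower number from compound 3 to compound 4 (0.05 log units; within the scatter)) that stays within the scatter. For compound 4 the estimated value is 500 nM with an expected range (180 nM to 1400 nM).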

Compound 4, half-maximal inhibitory concentration: 50 nM
The estimate for compound 4 lay 10-fold (1.00 log units) above the measured number; the measured number lies below the stated range.
By their numbers in this assay, from the lowest: compound 4; then compounds 3, 2 and 1 (each within the scatter of the next).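

Within this assay, hydrogen in place of methyl on an oxygen on a saturated carbon gives an 11-fold lower number from compound 3 to compound 4 (1.05 log units; beyond the scatter), the only step here between compounds that differ in one place. It shows that this end of the (hydroxymethyl)carbonyl group is not a silent position: methoxymethyl and hydroxymethyl are clearly distinguished, although the loss is only one heavy atom, and the earlier values could not separate any of the compounds. Nothing available accounts for the size of this step.

Going by these compounds, it remains open whether an amine, a carboxylic acid or a longer chain such as hydroxyethyl in place of hydroxymethyl would hold the value of compound 4. On these data alone, whether the step carries over to another core is also open, since compound 1 has no methoxymethyl partner on its own core.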